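Dinonyl core: amine-bearing side chain replaced by a diol

The source may report more compounds than this note shows. Statements on the series, on what has been measured and on what is new or still open speak of the compounds shown alone.

Of the compounds shown here, three have been read in a toxicity assay on the whole organism (J774 cells) for cytotoxicity, with Mus musculus as the target, read by MTT assay, with a stated time of 24 h, tested at 10 uM; a higher number here means a weaker effect of the compound at the concentration tested, a lower number a stronger effect. Compound 1 `CCCCCCCCCO[C@@H]1[C@@H](N)[C@@H](OCC(O)CNCCO)O[C@H](CN)[C@H]1OCCCCCCCCC` gives 99.1%, the highest of the three numbers and therefore the weakest effect. Compound 2 `NC[C@H]1O[C@H](O[C@H]2[C@H](O)[C@@H](O)[C@H](N)C[C@@H]2N)[C@H](N)[C@@H](OCc2ccc3ccccc3c2)[C@@H]1OCc1ccc2ccccc2c1` gives 79.1%, and compound 3 `NC[C@H]1O[C@H](O[C@H]2[C@H](O)[C@@H](OCc3ccc4ccccc4c3)[C@H](N)C[C@@H]2N)[C@H](N)[C@@H](OCc2ccc3ccccc3c2)[C@@H]1O` gives 86%; both sit beyond the scatter below compound 1, compound 3 being the nearer of the two. No pair among these three differs in only one place, so no single-point step has been measured in this assay.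

Compound 4 `CCCCCCCCCO[C@@H]1[C@@H](N)[C@@H](OCC(O)CO)O[C@H](CN)[C@H]1OCCCCCCCCC` is the next compound to be read. It differs from compound 1 by hydroxy in place of (2-hydroxyethyl)amino on a saturated chain carbon, two bonds along the chain from an oxygen on a saturated carbon, that is, the (2-hydroxyethyl)amino arm of the 2-hydroxy-3-((2-hydroxyethyl)amino)propyl chain is cut back to a 2,3-dihydroxypropyl chain on the same core. With compound 1 already close to full survival at 99.1%, the number can hardly move upward, and no step beyond the scatter is expected from compound 1 to compound 4 in this assay, the estimated step being a number 3.1 percentage points lower from compound 1 to compound 4 (within the scatter). Compound 4 is expected to give about 96%, within a range from 84% to 104%.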

Compound 4, a percentage reported as activity, at one concentration (the size of the read-out at that concentration, not a potency): 89.7%
The estimate for compound 4 lay 6.3 percentage points above the measured number; the measured number falls inside the stated range.
By their numbers in this assay, from the lowest: compounds 2, 3, 4 and 1 (each within the scatter of the next, the first and the last beyond it).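

In this assay, among these compounds, the first single-place step reads a number 9.4 percentage points lower from compound 1 to compound 4 (within the scatter), for the cut from 2-hydroxy-3-((2-hydroxyethyl)amino)propyl to 2,3-dihydroxypropyl on the shared core. At this place, on a saturated chain carbon, two bonds along the chain from an oxygen on a saturated carbon, hydroxy can therefore stand in for (2-hydroxyethyl)amino with no step beyond the usual scatter, so the nitrogen of that arm is not needed to keep the read-out within the scatter of compound 1. No supporting data bear on why the two compounds read as they do.

Open, as far as these compounds go, is how a primary amine or a carboxylic acid at this same place would read in this assay. Also open, from the compounds shown here alone, is whether the step would stay within the scatter with decyl chains in place of the nonyl chains of the shared core.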